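This account rests on a few compounds, and the source may have more. Where it says the series, first, only, none or still open, it means among the compounds named here.

Measured so far in an ADME assay on NCM460 cells (Homo sapiens) for cytotoxicity, read by MTT assay, with a stated time of 72 h; a higher number here means a weaker inhibitor, a lower number a stronger inhibitor:
compound 1 `COc1ccc(NC(=O)c2cccc(/C=C3\CC(=O)N(c4ccc(C)cc4)C3=O)c2)cc1` gives > 100000 nM.
compound 2 `O=C(Nc1ccccc1)c1cccc(/C=C2\CC(=O)N(c3ccccc3)C2=O)c1` gives > 100000 nM.
compound 3 `CCc1cccc(NC(=O)c2cccc(/C=C3\CC(=O)N(c4ccc(C)cc4)C3=O)c2)c1` gives > 100000 nM.

Each of these values is a limit of the assay, not a number. Compound 2 thus stands only at a limit in this assay, and the two other values shown stand there too. Among the compounds with values here, the one change that can be followed between measured compounds, a step that the two limits leave unreadable from compound 1 to compound 3, cannot be read because both ends sit at the limit of > 100000 nM in this assay, at which 3 of the 3 values shown sit. Compound 4 `O=C(NCc1ccccc1)c1cccc(/C=C2\CC(=O)N(c3ccccc3)C2=O)c1` differs from compound 2 by benzyl in place of phenyl on an amide-type nitrogen. Within the data shown here, no measured step covers a change of this kind, and the three values give no size for any step, so the expectation for compound 4 is a step that the limit leaves unreadable from compound 2 to compound 4 of no size beyond the scatter, most likely again a limit. Compound 4 is estimated at 150000 nM, between 60000 nM and 400000 nM.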

Compound 4, half-maximal inhibitory concentration: > 100000 nM
Compound 4 was reported as a limit (the forecaster's own chance of this, stated with the estimate: 85%); the middle value does not contradict the limit.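

In this assay, no step can be read from compound 2 to compound 4, because both values are limits and not numbers: the limit of > 100000 nM in this assay, at which 4 of the 4 values shown sit.

The compounds shown leave open whether any change to the shared core gives a value that can be read.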